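This account rests on a few compounds, and the source may have more. Where it says the series, first, only, none or still open, it means among the compounds named here.

Compound 1 `CC1(c2ccccc2)CC(=O)N(CC(=O)N2CCN(c3ccc(Cl)cc3)CC2)C1=O` gives 300 mg/kg in a functional assay on the whole organism (strain CD-1) with Mus musculus as the target, with a stated time of 0.5 h; a higher number here means that more compound is needed for the effect, a lower number that less compound is needed.
Compound 2 `CC1(c2ccccc2)CC(=O)N(CC(=O)N2CCC(Cc3ccccc3)CC2)C1=O` gives 100 mg/kg in this assay.
Compound 3 `CC1(c2ccccc2)CC(=O)N(CC(=O)N2CCN(c3ccccc3)CC2)C1=O` gives 100 mg/kg in this assay.

On these numbers compound 3 sits level with compound 2, and together the two hold the lowest numbers of the three, meaning the least compound is needed for the effect, while compound 1 needs the most. Going by the values given here, the one step measured within this set, a 3.0-fold lower number from compound 1 to compound 3 (0.48 log units; beyond the scatter), shows that when hydrogen takes the place of chloro on an aromatic carbon the number falls by a modest amount that lies beyond the scatter.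

Compound 4 `CC1(c2ccccc2)CC(=O)N(CC(=O)N2CCN(c3cccc(C(F)(F)F)c3)CC2)C1=O` differs from compound 3 in one place: trifluoromethyl in place of hydrogen on an aromatic carbon. Among the compounds with values here, the only measured step that bears on this change is the one from compound 1 to compound 3, where a group on an aromatic carbon was taken away and the number fell. Within the data shown here, in compound 4 a group is added instead, so the expectation is a modest rise in the number, though the group entering is a different one and no measured compound carries trifluoromethyl, which leaves the direction uncertain. The step expected from compound 3 to compound 4 is a 2.0-fold higher number from compound 3 to compound 4 (0.30 log units; within the scatter). Compound 4 is therefore estimated to give 200 mg/kg, with a range from 100 mg/kg to 400 mg/kg.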

Compound 4, minimum effective dose: "not active" (no number reported)
For compound 4 the study gives words and no number; there is nothing to compare the estimate with.
By their numbers in this assay, from the lowest: compounds 2 and 3 (each within the scatter of the next); then compound 1.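

Going by these compounds alone, compound 4 is reported in this assay only as not active, without a number, so no step from compound 3 to compound 4 can be read. No available evidence bears on this result. The compounds shown leave open how much compound, if any, would produce the effect with 3-(trifluoromethyl)phenyl in place of phenyl.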